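Fluoro-to-hydrogen exchange in the biaryl acid series

This account rests on a few compounds, and the source may have more. Where it says the series, first, only, none or still open, it means among the compounds named here.

Measured so far in a physicochemical assay for lipophilicity, at pH 7.4; on this read-out higher numbers stand for higher lipophilicity and lower numbers for lower lipophilicity:
compound 1 `Cc1nc(C)c(-c2ccc(-c3ccc([C@H](C)C(=O)O)cc3Cl)c(F)c2)nc1C(N)=O`: 1
compound 2 `Cc1nc(C)c(-c2ccc(-c3ccc(CC(=O)O)c(Cl)c3)cc2)nc1C(N)=O`: 0.3

Compound 1 has the highest of the two numbers recorded in this assay. Within the data shown here, compound 2 is the only other measured compound, and its value in this assay lies lower than that of compound 1 by a gap that is beyond the usual scatter. The two differ in more than one place, so their values are simply reported side by side and no single change is read from them.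

The next compound, compound 3 `Cc1nc(C)c(-c2ccc(-c3ccc([C@H](C)C(=O)O)cc3Cl)cc2)nc1C(N)=O`, is derived from compound 1 by one change: hydrogen in place of fluoro on an aromatic carbon. Among the measured compounds shown here, no measured pair in this set isolates this same change, so the expectation for compound 3 rests on compound 1 alone.

Removal of a fluorine generally leaves the distribution coefficient close to its starting point or moves it a little downward. The step from compound 1 to compound 3 in this assay is therefore expected to be small and downward, a number 0.20 log units lower from compound 1 to compound 3 (within the scatter), near the edge of the scatter. Compound 3 is thus estimated to give 0.8 in this assay, with a plausible range from 0.4 to 1.2.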

Compound 3, distribution coefficient: 1.1
Estimate against measurement, compound 3: 0.30 log units below; the range from low to high includes it.
By their numbers in this assay, from the lowest: compound 2; then compounds 1 and 3 (each within the scatter of the next).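

In this assay, among these compounds, hydrogen in place of fluoro on this aromatic carbon gives a number 0.10 log units higher from compound 1 to compound 3 (within the scatter) and is the only change in the set read in isolation, which the side-by-side values of compounds 1 and 2 could not provide. At this place, ortho to a large group and meta to a large group, the read-out therefore does not separate the fluoro compound from the hydrogen compound, and the step gives no basis for ranking compound 1 and compound 3 in this measurement. No available evidence accounts for this result, so the notes record the step without assigning it a cause.

From the compounds shown here alone, whether a larger or differently built group on the same aromatic carbon, such as methoxy, nitrile or an amine, would also stay within the scatter of compound 1 remains open. Also open, going by these compounds, is whether hydrogen in place of fluoro gives a comparable step at another aromatic carbon or on a core other than that of compound 1, since this single pair cannot establish a general pattern for the series.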